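The compounds below may be only part of what the source reports. "The series", "measured", "known", "first", "only" and "open" are said of these compounds alone.

Values in a functional assay on NALM-6 cells (Homo sapiens) for cytotoxicity, with a stated time of 72 h; on this read-out lower numbers stand for an effect already at smaller amounts and higher numbers for an effect only at larger amounts of compound:
compound 1 `C=C[C@@](C)(/C=C/c1ccc(O)cc1)CCC(O)C(C)(C)O`: > 43400 nM (a limit)
compound 2 `C=C[C@@](C)(/C=C/c1ccc(O)c(C=O)c1)CCC=C(C)C`: 11200 nM
compound 3 `C=C[C@@](C)(/C=C/c1ccc(O)c(/C=C/C#N)c1)CCC=C(C)C`: > 43400 nM (a limit)

Compound 3 gives no number, only the limit > 43400 nM. Compound 3 therefore stands on (the limit of > 43400 nM in this assay, at which 2 of the 3 values shown sit), and compound 2 is the only one of the three with a number.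

The next compound is compound 4 `C=C[C@@](C)(/C=C/c1ccc(O)c(/C=C/C(=O)O)c1)CCC=C(C)C`. The change from the preceding compound is carboxy in place of cyano on a double-bonded chain carbon bound to a double-bonded chain carbon: the 2-cyanoethenyl group becomes 2-carboxyethenyl. Among the measured compounds shown here, one measured step bears on this: an at least 3.8-fold higher number from compound 2 to compound 3 (0.58 log units; beyond the scatter). Going by these compounds, that step replaced formyl with 2-cyanoethenyl on an aromatic carbon, and it ended at the limit, so its full size is unknown. For the measured compounds named here, no measured step covers carboxy in place of cyano. Compound 4 keeps the ethenyl part that came in with that step, so no recovery in this assay is expected and no step beyond the scatter is anticipated. A further report at the limit is likely.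

The estimated step is an at least 1.0-fold lower number from compound 3 to compound 4 (0.03 log units; that floor lies within the scatter). For compound 4 the expected value is 40000 nM, with an estimated range of 14000 nM to 90000 nM.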

Compound 4, half-maximal effective concentration: > 43400 nM
Compound 4 gave a limit, no number; the forecaster's own chance of this, stated with the estimate: 70%; middle value at least 1.0-fold (0.03 log units) from the limit.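

Replacing the cyano end with carboxy does not bring back a measurable value in this assay, so the loss seen with 2-cyanoethenyl is not confined to that one end group; where the formyl group gives way to 2-carboxyethenyl, the result is an at least 3.8-fold higher number from compound 2 to compound 4 (0.58 log units; beyond the scatter). Compound 3 and compound 4 both report limits, so the step between them cannot be read and neither end group can be ranked. Compound 4 joins the other compounds reported only as a limit: the limit of > 43400 nM in this assay, at which 3 of the 4 values shown sit.

Going by these compounds, how far compound 3 and compound 4 lie past that limit remains open, and so does whether the ethenyl part or the end group drives the loss. An amine, or a saturated ethyl chain ending in a carboxylic acid, in place of formyl would help separate these two readings.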